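Sulfonamide sodium channel inhibitors: swapping the ring on nitrogen

The source may report more compounds than this note shows. Statements on the series, on what has been measured and on what is new or still open speak of the compounds shown alone.

Three compounds share a benzylamide core carrying a sulfonamide. Compound 1 `O=C(NCc1ccccc1)c1ccc(S(=O)(=O)Nc2nccs2)cc1` is the plain benzyl version; in an assay on cells for inhibition of sodium channel protein type 3 subunit alpha (Homo sapiens), read by electrophysiology (a lower number here means a stronger inhibitor, a higher number a weaker inhibitor), compound 1 gives 4450 nM. Compound 2 `O=C(NCc1ccc(OC(F)(F)F)c(Cl)c1)c1ccc(S(=O)(=O)Nc2nccs2)cc1` adds a trifluoromethoxy group and a chlorine to the benzyl ring, and in this assay compound 2 gives 20 nM. Compound 3 `O=C(NCc1ccc(OC(F)(F)F)c(Cl)c1)c1ccc(S(=O)(=O)Nc2ncns2)c(F)c1` further carries a fluorine on the central ring and a 1,2,4-thiadiazol-5-yl on the sulfonamide nitrogen; in this assay compound 3 gives 13 nM. The number for compound 3 sits within the scatter of compound 2 and far below that of compound 1, so compounds 2 and 3 cannot be told apart on these data.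

Compound 4 `O=C(NCc1ccc(OC(F)(F)F)c(Cl)c1)c1ccc(S(=O)(=O)Nc2ncccn2)c(F)c1` differs from compound 3 in one place: pyrimidin-2-yl in place of 1,2,4-thiadiazol-5-yl on a sulfonamide nitrogen. For the measured compounds named here, no measured pair shows this exchange, so the size of its effect is open. The expectation is a modest weakening, a step of a 3.1-fold higher number from compound 3 to compound 4 (0.49 log units; beyond the scatter) that may barely exceed the scatter. Compound 4 is therefore estimated at 40 nM in this assay, within a range from 13 nM to 130 nM.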

Compound 4, half-maximal inhibitory concentration: 374 nM
For compound 4 the middle estimate is 9.4-fold (0.97 log units) below the measured one, and the stated range ends below it.
By their numbers in this assay, from the lowest: compounds 3 and 2 (each within the scatter of the next); then compound 4; then compound 1.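

In this assay, for the compounds shown here, the ring on the sulfonamide nitrogen proves to be far from interchangeable: the one exchange gives a 29-fold higher number from compound 3 to compound 4 (1.46 log units; beyond the scatter), the only step here in which a single place changes. A six-membered aromatic ring with 2 hetero atoms therefore does not stand in for a five-membered aromatic ring with 3 hetero atoms at this place, at least on this core, although one pair sets no general rule. Nothing measured here accounts for the size of this loss.

From the compounds shown here alone, this single exchange alters ring size, the number of hetero atoms and the presence of sulfur together, so their separate contributions remain open. An oxazolyl ring on the same nitrogen would keep five ring atoms without sulfur, while a pyridyl ring would keep six with fewer ring nitrogens.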